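Methyl to Methoxy on the Amide Aryl Ring: Three Compounds

The compounds below may be only part of what the source reports. "The series", "measured", "known", "first", "only" and "open" are said of these compounds alone.

Compound 1 `Cc1cccc(NC(=O)c2c(O)c3cccnc3n(-c3ccccc3)c2=O)c1` carries a 3-methylphenyl group on its amide-type nitrogen. In a functional assay on the whole organism for inhibition, with Rattus norvegicus as the target, read by cytopathic effect and paw edema, at a dose of 100 mg/kg by the oral route (on this read-out lower numbers stand for less inhibition and higher numbers for more inhibition at the one dose given (going by the name of the read-out)), compound 1 gives 4.5%. Compound 2 `COc1cccc(NC(=O)c2c(O)c3cccnc3n(-c3ccccc3)c2=O)c1` differs from it by methoxy in place of methyl on an aromatic carbon, and in this assay compound 2 gives 20.7%, so that a number 16.2 percentage points higher from compound 1 to compound 2 (beyond the scatter). Compound 3 `Cc1ccccc1NC(=O)c1c(O)c2cccnc2n(-c2ccccc2)c1=O` is built from the same atoms as compound 1 and differs by 2-methylphenyl in place of 3-methylphenyl on an amide-type nitrogen. In this assay compound 3 gives 9.8%; a number 5.3 percentage points higher from compound 1 to compound 3 (within the scatter), while a number 10.9 percentage points lower from compound 2 to compound 3 (beyond the scatter).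

Compound 4 `COc1ccccc1NC(=O)c1c(O)c2cccnc2n(-c2ccccc2)c1=O` has not yet been measured. It differs from compound 3 by methoxy in place of methyl on an aromatic carbon. This is the same kind of change as that from compound 1 to compound 2, but the place is not the same: in compound 2 the methoxy sits meta to a large group, in compound 4 ortho to a large group. Because a number 16.2 percentage points higher from compound 1 to compound 2 (beyond the scatter) was measured with the methoxy meta to a large group, compound 4 is expected to show a step of a number 10.2 percentage points higher from compound 3 to compound 4 (beyond the scatter), smaller than that earlier one. Compound 4 is therefore estimated at 20%, within a range from 5% to 38%.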

Compound 4, a percentage reported as inhibition, in the whole organism at one dose (the size of the read-out at that dose, not a potency): -10.1%
Compound 4: middle estimate off by 30.1 percentage points, on the high side; measured number below the stated range.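

In this assay the exchange of methyl for methoxy on an aromatic carbon did not carry over between the two aryl groups, and its direction reversed: the same change on two cores in this assay, a number 16.2 percentage points higher (beyond the scatter) from compound 1 to compound 2 and a number 19.9 percentage points lower (beyond the scatter) from compound 3 to compound 4, 36.1 percentage points apart, beyond the scatter of two such steps. Compound 4 falls short of all three other compounds, with a number 19.9 percentage points lower from compound 3 to compound 4 (beyond the scatter), a number 30.8 percentage points lower from compound 2 to compound 4 (beyond the scatter) and a number 14.6 percentage points lower from compound 1 to compound 4 (beyond the scatter), so the step measured for 3-methylphenyl to 3-methoxyphenyl gave no usable guide to the step for 2-methylphenyl to 2-methoxyphenyl. Within the data shown here, this rests on only two matched pairs at a single oral dose, so it shows that the step differs between these pairs but neither explains the reversal nor establishes a rule for other aryl groups.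

The compounds shown leave open whether an ethoxy group, a hydroxyl or an amine in place of the methoxy would follow compound 2 or compound 4. They also leave open whether the reversal would persist with a carboxylic acid elsewhere on the amide aryl ring.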